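Replacing the amino group of compound 3 with an indole

The source may hold more compounds than are shown below. What is called first, only, known or untested is meant among the compounds shown, and "the series" means these compounds.

The shared core of compound 3 `Nc1cc(/C=C/c2ccccc2)nc2ccccc12` carries an amino group on the ring system, and in an ADME assay on J774 cells (Mus musculus) for cytotoxicity, read by MTT assay, with a stated time of 48 h (on this read-out higher numbers stand for weaker inhibition and lower numbers for stronger inhibition), compound 3 gives 4400 nM. Two neighbours alter that nitrogen. Compound 1 `NCCCCNc1cc(/C=C/c2ccccc2)nc2ccccc12` bears a 4-aminobutyl chain there and gives 6600 nM; the step of a 1.5-fold lower number from compound 1 to compound 3 (0.18 log units; within the scatter) leaves compound 3 and compound 1 within the scatter of each other. Compound 2 `CC(=O)Nc1cc(/C=C/c2ccccc2)nc2ccccc12` carries an acetyl on the same nitrogen, and its result in this assay is a limit, > 25000 nM. The step of an at least 5.6-fold lower number from compound 2 to compound 3 (0.75 log units; beyond the scatter) is therefore the only one of the two that is beyond the scatter, and it runs in favour of the free amino group (the limit of > 25000 nM in this assay, at which 1 of the 3 values shown sits).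

Compound 4 `C(=C/c1cc(-c2c[nH]c3ccccc23)c2ccccc2n1)\c1ccccc1` departs further from compound 3: 1H-indol-3-yl in place of amino on an aromatic carbon. Within the data shown here, no measured compound carries a ring in this position, so the two steps at the amino nitrogen are only indirect guides. The acetyl step shows that capping or removing the free amino group can push the number upward, while the 4-aminobutyl step shows that a larger substituent need not. For compound 4 a modest rise in this assay is expected, a 2.0-fold higher number from compound 3 to compound 4 (0.31 log units; beyond the scatter), with the estimate at 9000 nM and a range from 3000 nM to 25000 nM.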

Compound 4, half-maximal inhibitory concentration: 4100 nM
Beside the measured number, compound 4's estimate is 2.2-fold (0.34 log units) above it, within the range that was stated.
By their numbers in this assay, from the lowest: compounds 4, 3 and 1 (each within the scatter of the next). At a limit, above all of these: compound 2.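

The 1H-indol-3-yl group brings two aromatic rings onto the aromatic carbon opposite the ring nitrogen, yet in this assay the change from the amino group gives a 1.1-fold lower number from compound 3 to compound 4 (0.03 log units; within the scatter), so this position accepts a ring-bearing group without a change beyond the scatter. Set against the (4-aminobutyl)amino group, the same ring-bearing group gives a 1.6-fold lower number from compound 1 to compound 4 (0.21 log units; within the scatter), and compounds 1, 3 and 4 therefore cannot be put in any order here, although compound 4 joins this position through a carbon rather than a nitrogen. Among the compounds shown, only the acetamido group stands apart, with an at least 6.0-fold lower number from compound 2 to compound 4 (0.78 log units; beyond the scatter), a step read from a limit: the limit of > 25000 nM in this assay, at which 1 of the 4 values shown sits.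

The compounds shown leave open whether the hydrogen on the indole nitrogen matters, which a 1-methylindol-3-yl group would test, and whether a plain phenyl ring on the same carbon would fit with these three compounds. They also leave open whether the result for compound 2 belongs to the carbonyl of the acetamido group, a question that a methylamino group or a longer propanamido group would help to separate.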